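The source may hold more compounds than are shown below. What is called first, only, known or untested is meant among the compounds shown, and "the series" means these compounds.

Compound 3 `Cc1nc2c(OCc3ccsc3)cccn2c1N` stands lowest of the three numbers in hand. In a functional assay on the whole organism with Rattus norvegicus as the target, at a dose of 40 mg/kg by the intraperitoneal route (on this read-out higher numbers stand for more inhibition at the one dose given (going by the name of the read-out) and lower numbers for less inhibition), compound 3 gives 52%; compound 2 `Cc1nc2c(OCc3cccs3)cccn2c1N` gives 70%; compound 1 `Cc1nc2c(OCc3ccccc3)cccn2c1N` gives 99%. The steps among them are a number 29 percentage points lower from compound 1 to compound 2 (beyond the scatter), a number 47 percentage points lower from compound 1 to compound 3 (beyond the scatter) and a number 18 percentage points lower from compound 2 to compound 3 (beyond the scatter), each beyond the scatter. Compound 4 `Cc1nc2c(Oc3ccccc3)cccn2c1N` differs from compound 3 in one place: phenyl in place of (thiophen-3-yl)methyl on an oxygen on an aromatic ring. Two things change at once here: the aromatic group goes back from thiophen-3-yl to phenyl, and the saturated chain carbon between it and the oxygen on the aromatic ring is gone. Among the compounds with values here, only the first part has a measured counterpart, the large step of a number 47 percentage points lower from compound 1 to compound 3 (beyond the scatter) run in reverse; the removal of the chain carbon has no measured step, so the size of the move is uncertain and the expectation rests on the ring change alone. An increase is therefore expected, a number 23 percentage points higher from compound 3 to compound 4 (beyond the scatter), with a wide range. Compound 4 is expected to give 75%, between 40% and 99%.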

Compound 4, a percentage reported as inhibition, in the whole organism at one dose (the size of the read-out at that dose, not a potency): 34%
Estimate against measurement, compound 4: 41 percentage points above, and the stated range ends above it.
By their numbers in this assay, from the lowest: compound 4; then compound 3; then compound 2; then compound 1.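

In this assay, replacing the (thiophen-3-yl)methyl group with phenyl gives a number 18 percentage points lower from compound 3 to compound 4 (beyond the scatter), and replacing the (thiophen-2-yl)methyl group gives a number 36 percentage points lower from compound 2 to compound 4 (beyond the scatter), so going back to phenyl does not by itself restore the level of the earlier phenyl compound. Compound 1 gives 99% and compound 4 gives 34%; this pair carries the same phenyl and differs only in the saturated chain carbon, so the advantage of phenyl over the thiophene rings, seen so far only with that carbon present, does not carry over to a phenyl sitting directly on the oxygen. No measurement at hand accounts for this loss.

Still open, going by these compounds, is how a longer chain carrying the phenyl on the oxygen would compare with compound 1. Also open, on these data alone, is whether thiophen-3-yl or thiophen-2-yl directly on the oxygen would follow compound 4.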